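The source may hold more compounds than are shown below. What is called first, only, known or untested is meant among the compounds shown, and "the series" means these compounds.

Three compounds share one core and differ only in the aromatic ring that hangs from its ether oxygen. In a physicochemical assay for solubility, read by HPLC, measured as thermodynamic solubility, with a stated time of 4 h, at pH 6.8 (on this read-out higher numbers stand for higher solubility and lower numbers for lower solubility), compound 1 `Cn1c(COc2cccc(C(=O)O)c2)nc2ccc(Oc3ccc(F)cc3)nc21` gives 11 ug/mL, compound 2 `Cc1ccc(Oc2ccc3nc(COc4cccc(C(=O)O)c4)n(C)c3n2)cc1` gives 33 ug/mL, and compound 3 `Cn1c(COc2cccc(C(=O)O)c2)nc2ccc(Oc3ccccn3)cc21` gives 62 ug/mL, the highest number of the three, though its gap to compound 2 lies within the scatter and only its gap to compound 1 lies beyond it. Compound 4 `Cc1cccnc1Oc1ccc2nc(COc3cccc(C(=O)O)c3)n(C)c2c1` differs from compound 3 by methyl in place of hydrogen on an aromatic carbon. For the measured compounds named here, the single measured step, a 3.0-fold higher number from compound 1 to compound 2 (0.48 log units; beyond the scatter), concerns a different exchange on a different ring and bears only loosely on this change. A step in this assay no larger than the scatter is therefore expected, a 1.2-fold lower number from compound 3 to compound 4 (0.09 log units; within the scatter). Compound 4 is estimated at 50 ug/mL, with a range from 18 ug/mL to 140 ug/mL.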

Compound 4, solubility: 37 ug/mL
Estimate against measurement, compound 4: 1.4-fold (0.13 log units) above; measured number inside the range.
By their numbers in this assay, from the lowest: compound 1; then compounds 2, 4 and 3 (each within the scatter of the next).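

Placing a methyl on the aromatic carbon that turns pyridin-2-yl into 3-methylpyridin-2-yl gives, in this assay, a 1.7-fold lower number from compound 3 to compound 4 (0.22 log units; within the scatter), so the two compounds cannot be told apart on this read-out. This is the first step shown on this ring, and at this one position a single added carbon produces no difference larger than the scatter. No measurement offered here explains the result.

From the compounds shown here alone, whether a methoxy or an amine at this carbon would give a step beyond the scatter remains open. So does the outcome of a methyl on another carbon of this ring.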